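The source may hold more compounds than are shown below. What is called first, only, known or untested is meant among the compounds shown, and "the series" means these compounds.

Measured so far:
compound 1, `CCCCNc1nc(N)nc2cccc(CCc3ccccc3)c12`: 0.47 uM
compound 2, `CCCCNc1nc(N)nc2cccc(OCCOC)c12`: 0.2 uM

In an ADME assay on HEK293 cells for agonist activity at Toll-like receptor 8 (Homo sapiens), read by a luciferase reporter, with a stated time of 6 h (on this read-out higher numbers stand for an effect only at larger amounts of compound and lower numbers for an effect already at smaller amounts), compound 1 gives 0.47 uM and compound 2 gives 0.2 uM. Compound 2 stands lowest of the two numbers; its nearest neighbour is compound 1. For the measured compounds named here, the only measured step between them is a 2.4-fold lower number from compound 1 to compound 2 (0.37 log units; beyond the scatter), a modest step that nonetheless lies beyond the scatter, brought about by 2-methoxyethoxy in place of phenethyl on an aromatic carbon.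

Compound 3, `CCCCNc1nc(N)nc2cccc(OCc3ccccc3)c12`, is not yet measured in this assay. It differs from compound 2 by phenyl in place of methoxymethyl on a saturated chain carbon bound to an oxygen on an aromatic ring. This change reintroduces an aromatic ring in the side chain while keeping the oxygen on the aromatic ring, so compound 3 lies between compound 1 and compound 2 in its make-up. Going by the values given here, since the one measured step ran toward a lower number when the aryl group was removed, the reverse move is expected to give a small rise, roughly at the edge of the scatter: a 1.8-fold higher number from compound 2 to compound 3 (0.24 log units; within the scatter). Compound 3 is therefore expected to give about 0.35 uM, within a range from 0.15 uM to 0.8 uM.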

Compound 3, minimum effective concentration: 1.66 uM
Estimate against measurement, compound 3: 4.7-fold (0.68 log units) below; measured number outside the range, above it.
By their numbers in this assay, from the lowest: compound 2; then compound 1; then compound 3.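

In this assay benzyloxy in place of 2-methoxyethoxy gives an 8.3-fold higher number from compound 2 to compound 3 (0.92 log units; beyond the scatter), the largest step seen so far at this position, so the part of the side chain further from the core counts heavily here and an oxygen on the aromatic ring does not by itself secure a low number. Benzyloxy in place of phenethyl gives a 3.5-fold higher number from compound 1 to compound 3 (0.55 log units; beyond the scatter), which leaves the oxygen-linked compound 3 with the highest number of the three, while compound 1, which carries an all-carbon link to its phenyl ring, stands in the middle and the oxygen-linked compound 2 stands lowest. The two oxygen-linked compounds therefore lie at opposite ends of this short series, and nothing available accounts for the size or direction of these steps.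

What the compounds shown leave open is whether the low number of compound 2 goes with the ether oxygen in its chain or simply with the absence of a phenyl ring, a question that a plain butoxy chain would help to separate. Also open, as far as these compounds go, is how a 2-aminoethoxy group or a carboxylic acid at the end of the chain would fare at this position.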